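Ester series: nitrophenyl for dichlorophenyl on the benzoate

The source may report more compounds than this note shows. Statements on the series, on what has been measured and on what is new or still open speak of the compounds shown alone.

Two members of this series have numbers. In a functional assay on HeLa cells (Homo sapiens) for inhibition, read by sulforhodamine B assay, with a stated time of 48 h (on this read-out lower numbers stand for stronger inhibition of growth and higher numbers for weaker inhibition of growth), compound 2 `O=C(OC/C(=C/c1ccc(Cl)cc1Cl)C(=O)c1ccccc1)c1ccccc1` gives 8300 nM, the lowest of the two; compound 1 `CC(=O)OC/C(=C/c1ccccc1[N+](=O)[O-])C(=O)c1ccccc1`, the acetate carrying the same aryl as the compound still to be made, gives 78000 nM in this assay, a gap beyond the scatter. Compounds 1 and 2 differ in two places at once, so no single step can be read from them.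

Compound 3 `O=C(OC/C(=C/c1ccccc1[N+](=O)[O-])C(=O)c1ccccc1)c1ccccc1` keeps the benzoate of compound 2 and changes only the aryl: 2-nitrophenyl in place of 2,4-dichlorophenyl on a double-bonded chain carbon bound to a double-bonded chain carbon. Among the measured compounds shown here, no pair with this exact change has been measured, so the size of the step rests on indirect evidence. The only measured carrier of 2-nitrophenyl, compound 1, stands well above compound 2 in this assay, which points toward a weaker result for compound 3, though part of that gap may belong to the ester.

The step from compound 2 to compound 3 is therefore expected to be a 3.6-fold higher number from compound 2 to compound 3 (0.56 log units; beyond the scatter), beyond the scatter and toward weaker inhibition. For compound 3 the estimate in this assay is 30000 nM, with a range from 10000 nM to 90000 nM.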

Compound 3, concentration for 50% growth inhibition: 30000 nM
The estimate for compound 3 equals the measured number at the digits printed; measured number inside the range.
By their numbers in this assay, from the lowest: compound 2; then compound 3; then compound 1.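

In this assay, among the compounds shown here, the exchange of 2,4-dichlorophenyl for 2-nitrophenyl on a double-bonded chain carbon bound to a double-bonded chain carbon, with the benzoate held fixed, gives a 3.6-fold higher number from compound 2 to compound 3 (0.56 log units; beyond the scatter) and so provides the first direct reading at this position, with 2,4-dichlorophenyl giving the stronger inhibition of growth of the pair. Compound 3 also supplies a second single-place comparison: with 2-nitrophenyl held fixed, phenyl in place of methyl on a carbonyl carbon gives a 2.6-fold lower number from compound 1 to compound 3 (0.41 log units; beyond the scatter) and shows that the ester also moves the number, in favour of the benzoate over the acetate. The large gap between compound 1 and compound 2 can thus be read as two separate changes, both modest and both beyond the scatter, and no available measurement explains either one.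

As far as these compounds go, whether the benzoate keeps its advantage over the acetate when the aryl group is 2,4-dichlorophenyl remains open, as two steps sharing compound 3 cannot show whether the changes act independently. Also open, from the compounds shown here alone, is how this assay would respond to an amine on the aryl ring or a longer alkyl chain in place of the methyl on the carbonyl carbon.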